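A few compounds are considered here, and "the series" means these few. Any claim that something is new, unique, unknown or untested is made for them only; others in the source may bear on it.

Measured in a functional assay on MCF7 cells (Homo sapiens) for antiproliferative activity, read by MTT assay, with a stated time of 72 h; a lower number here means a stronger inhibitor, a higher number a weaker inhibitor:
- compound 1 `CCCCOc1ccc(C2=C(c3ccc(O)cc3)[C@H]3C[C@H](S(=O)(=O)N(CC)c4ccccc4)[C@@H]2O3)cc1`: 3290 nM
- compound 2 `CCCCCCOc1ccc(C2=C(c3ccc(O)cc3)[C@H]3C[C@H](S(=O)(=O)N(CC)c4ccccc4)[C@@H]2O3)cc1`: 3450 nM
- compound 3 `CCCCCCOc1ccc(N(C)S(=O)(=O)[C@H]2C[C@H]3O[C@@H]2C(c2ccc(O)cc2)=C3c2ccc(O)cc2)cc1`: 4140 nM

Compound 3, at 4140 nM, lies within the scatter of compound 1 and compound 2, so the three values do not separate. Compound 4 `CCCCCCOc1ccc(N(CC)S(=O)(=O)[C@H]2C[C@H]3O[C@@H]2C(c2ccc(O)cc2)=C3c2ccc(O)cc2)cc1` differs from compound 3 by methyl in place of hydrogen on a saturated chain carbon bound to a sulfonamide nitrogen, that is, methyl to ethyl on the sulfonamide nitrogen. For the measured compounds named here, no measured step covers this place. Going by the values given here, the only measured step, a 1.0-fold higher number from compound 1 to compound 2 (0.02 log units; within the scatter), is a chain change at another place and stays within the scatter. Nothing beyond the scatter is therefore expected in this assay, and no direction can be assigned. The expected move is a 1.1-fold lower number from compound 3 to compound 4 (0.03 log units; within the scatter). Compound 4 is estimated at 3900 nM, with an expected range of 2100 nM to 7200 nM.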

Compound 4, half-maximal inhibitory concentration: 1480 nM
Compound 4: middle estimate off by 2.6-fold (0.42 log units), on the high side; measured number outside the range, below it.
By their numbers in this assay, from the lowest: compound 4; then compounds 1, 2 and 3 (each within the scatter of the next).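

In this assay, for the compounds shown here, the methyl to ethyl change on the sulfonamide nitrogen gives a 2.8-fold lower number from compound 3 to compound 4 (0.45 log units; beyond the scatter) and is the only step so far to leave the scatter. The chain change at the other place gives a 1.0-fold higher number from compound 1 to compound 2 (0.02 log units; within the scatter) and stays within it, so this position responds to one added carbon where that chain did not. No measurement on hand bears on the reason for this step.

As far as these compounds go, whether the number falls further with a propyl or longer chain on the sulfonamide nitrogen stays open. So does the effect of a hydroxyethyl or aminoethyl group there.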